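The compounds below may be only part of what the source reports. "The series", "measured", "known", "first", "only" and "open" are said of these compounds alone.

Measured so far in an ADME assay on BSC cells (Cercopithecidae) for cytotoxicity; a higher number here means a weaker inhibitor, a lower number a stronger inhibitor:
compound 1 `Nc1ncnc2c1ccn2COC(CO)CO` — > 100000 nM
compound 2 `CCNc1ncnc2c1c(Br)cn2COC(CO)CO` — > 100000 nM

Both readings are limits of this assay, not numbers. Compound 1 returns only the limit > 100000 nM in this assay. Compound 2 likewise returns only the limit > 100000 nM in this assay. On the numbers shown compound 2 therefore cannot be placed relative to anything: it sits at the limit together with compound 1, as recorded in the limit of > 100000 nM in this assay, at which 2 of the 2 values shown sit.

Compound 3 `CNc1ncnc2c1c(Br)cn2COC(CO)CO` differs from compound 2 by hydrogen in place of methyl on a saturated chain carbon bound to a nitrogen on an aromatic ring. Going by the values given here, no measured step covers this change, so the expectation rests on the two limits alone. The change from ethylamino to methylamino is expected to shift this assay by nothing beyond the scatter, in no particular direction. The expected step from compound 2 to compound 3 is a step that the limit leaves unreadable from compound 2 to compound 3, essentially none. For compound 3 the estimate in this assay is 150000 nM, with a range from 50000 nM to 500000 nM, and the assay is expected most likely to report only its limit again.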

Compound 3, half-maximal inhibitory concentration: > 100000 nM
Compound 3: no number, only a limit; the forecaster's own chance of this, stated with the estimate: 85%; the middle value lies beyond the limit too.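

Compound 3 in this assay gives only a limit, > 100000 nM. No step can be read between compound 2 and compound 3, as all the values shown sit at one limit: the limit of > 100000 nM in this assay, at which 3 of the 3 values shown sit.

The compounds shown leave open at what concentration, if any, each would reach half-maximal inhibition in this assay, and whether ethylamino versus methylamino makes any difference.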